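This account rests on a few compounds, and the source may have more. Where it says the series, first, only, none or still open, it means among the compounds named here.

In a functional assay on SNB-75 cells (Homo sapiens) for inhibition, read by sulforhodamine B assay, with a stated time of 48 h, tested at 10 uM (on this read-out higher numbers stand for more inhibition at the one concentration tested (going by the name of the read-out) and lower numbers for less inhibition), compound 2 `c1ccc2c(-c3cn4ccnc4c(-c4ccc5ncn(C6CCCCC6)c5c4)n3)cccc2c1` gives 16.5%, while compound 1 `O=Cc1ccc(-c2cn3ccnc3c(-c3ccc4ncn(C5CCCCC5)c4c3)n2)cc1` gives 21.4%, so the two numbers sit within the scatter of each other. Compound 3 `Brc1ccc(-c2cn3ccnc3c(-c3ccc4ncn(C5CCCCC5)c4c3)n2)cc1` differs from compound 2 in one group on the shared core: 4-bromophenyl in place of naphthalen-1-yl on an aromatic carbon. Going by the values given here, one measured step bears on this kind of exchange of one aryl group for another on the shared core, a number 4.9 percentage points lower from compound 1 to compound 2 (within the scatter), and it stayed within the scatter. No shift beyond the scatter is therefore expected here. Compound 3 is estimated at 19%, between 4% and 34%, an expected step of a number 2.5 percentage points higher from compound 2 to compound 3 (within the scatter).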

Compound 3, a percentage reported as inhibition, at one concentration (the size of the read-out at that concentration, not a potency): 34.6%
Beside the measured number, compound 3's estimate is 15.6 percentage points below it, and the stated range ends below it.
By their numbers in this assay, from the lowest: compounds 2 and 1 (each within the scatter of the next); then compound 3.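

In this assay this position on the shared core proves able to move the read-out: there is a number 18.1 percentage points higher from compound 2 to compound 3 (beyond the scatter) and also a number 13.2 percentage points higher from compound 1 to compound 3 (beyond the scatter), whereas the earlier exchange of one aryl group for another stayed within the scatter. Among the three compounds, 4-bromophenyl therefore stands apart from both other aryl groups, though the gain is modest. Nothing measured here gives a reason for this gain. From the compounds shown here alone, whether a 4-chlorophenyl or a 4-aminophenyl group in the same place would match 4-bromophenyl stays open. So does whether any group here could lift the inhibition much further.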